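Compound 4: nitro in place of bromo, expected value

The compounds below may be only part of what the source reports. "The series", "measured", "known", "first", "only" and "open" are said of these compounds alone.

Three compounds of the series have numbers in a functional assay on K562 cells (Homo sapiens) for inhibition, read by MTT assay, with a stated time of 96 h; a lower number here means a stronger inhibitor, a higher number a weaker inhibitor. Compound 1 `COc1ccc(/C=C/C(=O)Nc2nc(-c3c(C)cc(C)cc3C)cs2)cc1` gives 4160 nM. Compound 2 `CCOc1ccc(/C=C/C(=O)Nc2nc(-c3c(C)cc(C)cc3C)cs2)cc1` gives 2480 nM in this assay, and compound 3 `Cc1cc(C)c(-c2csc(NC(=O)/C=C/c3ccc(Br)cc3)n2)c(C)c1` gives 4590 nM. Compound 3 holds the highest of the three numbers, yet the step of a 1.1-fold higher number from compound 1 to compound 3 (0.04 log units; within the scatter) and the step of a 1.9-fold higher number from compound 2 to compound 3 (0.27 log units; within the scatter) both stay within the scatter, so no order among the three can be read from these values. The step of a 1.7-fold lower number from compound 1 to compound 2 (0.22 log units; within the scatter) is likewise within the scatter.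

Compound 4 `Cc1cc(C)c(-c2csc(NC(=O)/C=C/c3ccc([N+](=O)[O-])cc3)n2)c(C)c1` differs from compound 3 by nitro in place of bromo on an aromatic carbon. The change sits at the same aromatic carbon as the two measured exchanges, bromo for methoxy and bromo for ethoxy, and both of those steps were within the scatter. Among the compounds with values here, nothing measured bears on a nitro group itself; the only guide is that three different groups at this carbon gave numbers within the scatter of one another. The expectation for compound 4 in this assay is therefore a step of a 1.0-fold lower number from compound 3 to compound 4 (0.01 log units; within the scatter), which is within the scatter. Compound 4 is estimated at 4500 nM, with a range from 1800 nM to 11000 nM.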

Compound 4, half-maximal inhibitory concentration: 32200 nM
Beside the measured number, compound 4's estimate is 7.2-fold (0.85 log units) below it; the measured number lies above the stated range.
By their numbers in this assay, from the lowest: compounds 2, 1 and 3 (each within the scatter of the next); then compound 4.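

In this assay this aromatic carbon turns out not to be indifferent to its substituent: the 4-bromophenyl to 4-nitrophenyl change gives a clear loss (a 7.0-fold higher number from compound 3 to compound 4 (0.85 log units; beyond the scatter)), and the exchanges of methoxy and ethoxy for nitro point the same way (a 7.7-fold higher number from compound 1 to compound 4 (0.89 log units; beyond the scatter); a 13-fold higher number from compound 2 to compound 4 (1.11 log units; beyond the scatter)). The earlier flat picture therefore holds only for bromo, methoxy and ethoxy, which stay within the scatter of one another, while compound 4 stands apart as the weakest inhibitor of the four, and the step from the ethoxy compound is the only one graded large. Nothing available on these compounds accounts for the loss, so the nitro step stands as an observation without an explanation.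

Still open, as far as these compounds go, is whether an amine, a carboxylic acid or a nitrile at this carbon would stay with bromo, methoxy and ethoxy or fall away with nitro, so the nitro result cannot yet be read as a trend across groups. From the compounds shown here alone, all four compounds share the same core, so it is also open whether nitro in place of bromo carries a step of this size on any other core.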